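The source may report more compounds than this note shows. Statements on the series, on what has been measured and on what is new or still open speak of the compounds shown alone.

Series notes. In an ADME assay on MT4 cells (Homo sapiens) for inhibition (a higher number here means that more compound is tolerated, a lower number that less compound is tolerated), compound 1 `Cc1cn([C@@H]2O[C@H](CO[Si](C)(C)C(C)(C)C)[C@@]3(OS(=O)(=O)C=C3N)[C@H]2O[Si](C)(C)C(C)(C)C)c(=O)n(CC(=O)O)c1=O` gives only a limit, > 155000 nM. Compound 2 `CNC(=O)CCCCn1c(=O)c(C)cn([C@@H]2O[C@H](CO[Si](C)(C)C(C)(C)C)[C@@]3(OS(=O)(=O)C=C3N)[C@H]2O[Si](C)(C)C(C)(C)C)c1=O` likewise gives only a limit in this assay, > 250000 nM. Between these two stands a step that the two limits leave unreadable from compound 1 to compound 2, so the size of that change cannot be read. Within the data shown here, compound 2 thus sits at its own limit, and the one further value shown is also a limit (the limit of > 155000 nM in this assay, at which 1 of the 2 values shown sits, (the limit of > 250000 nM in this assay, at which 1 of the 2 values shown sits)). Compound 3 `CCCn1c(=O)c(C)cn([C@@H]2O[C@H](CO[Si](C)(C)C(C)(C)C)[C@@]3(OS(=O)(=O)C=C3N)[C@H]2O[Si](C)(C)C(C)(C)C)c1=O` differs from compound 2 by hydrogen in place of (methylcarbamoyl)methyl on a saturated chain carbon, three bonds along the chain from an aromatic nitrogen. No measured step bears on this change: the single step shown is unreadable, and both values reach only limits. No shift beyond the scatter in this assay is therefore expected, and the estimated step is an at least 1.2-fold lower number from compound 2 to compound 3 (0.09 log units; that floor lies within the scatter). Compound 3 is expected to give about 200000 nM in this assay, within 100000 nM to 400000 nM, most likely reported again only as a limit.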

Compound 3, half-maximal cytotoxic concentration: 75000 nM
Beside the measured number, compound 3's estimate is 2.7-fold (0.43 log units) above it, and the stated range ends above it.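

In this assay, hydrogen in place of (methylcarbamoyl)methyl gives an at least 3.3-fold lower number from compound 2 to compound 3 (0.52 log units; beyond the scatter), and ethyl in place of carboxy gives an at least 2.0-fold lower number from compound 1 to compound 3 (0.31 log units; beyond the scatter). The chain on the aromatic nitrogen therefore matters in this assay: among the compounds shown, the plain propyl chain of compound 3 carries the lowest number, with both steps beyond the scatter. The first of these steps gives only a minimum size because compound 2 sits at a limit: the limit of > 250000 nM in this assay, at which 1 of the 3 values shown sits.

The step between compound 1 and compound 2 cannot be read, as both values are limits, so the carboxy-bearing and amide-bearing chains cannot be ranked against each other. Going by these compounds, it remains open whether a longer plain alkyl chain or a propyl chain ending in an amine would give a number nearer that of compound 3 or nearer the limits.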